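This account rests on a few compounds, and the source may have more. Where it says the series, first, only, none or still open, it means among the compounds named here.

Measured so far:
Compound 1 `CC(C)N(C)c1nc2ccc(NC(=O)CCc3ccc(C(F)(F)F)cc3)cc2[nH]1` — in an assay on CHO-K1 cells for displacement of a labelled ligand from melanin-concentrating hormone receptor 1 (Homo sapiens), read by scintillation counting (a higher number here means a weaker inhibitor, a lower number a stronger inhibitor), compound 1 gives 5.9 nM.
Compound 2 `CN(c1nc2ccc(NC(=O)CCc3ccc(C(F)(F)F)cc3)cc2[nH]1)C1CCOC1` — in this assay compound 2 gives 27 nM.

Within the data shown here, compound 2 holds the highest of the two numbers; its only neighbour is compound 1, and the step of a 4.6-fold higher number from compound 1 to compound 2 (0.66 log units; beyond the scatter) separates them. Compound 3 `CN(c1nc2ccc(NC(=O)CCc3ccc(C(F)(F)F)cc3)cc2[nH]1)C1CCCCC1` is not yet measured. The change from compound 2 to compound 3 is cyclohexyl in place of oxolan-3-yl on a nitrogen on an aromatic ring. Among the measured compounds shown here, only the step from compound 1 to compound 2 bears on it, and that step shows a moderate loss. Removing the ring oxygen again is expected to recover part of that loss, so a moderate step downward is estimated, a 3.0-fold lower number from compound 2 to compound 3 (0.48 log units; beyond the scatter). Compound 3 is expected near 9 nM, within 3 nM to 30 nM.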

Compound 3, half-maximal inhibitory concentration: 6.7 nM
Beside the measured number, compound 3's estimate is 1.3-fold (0.13 log units) above it; measured number inside the range.
By their numbers in this assay, from the lowest: compounds 1 and 3 (each within the scatter of the next); then compound 2.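

In this assay, cyclohexyl in place of oxolan-3-yl on this nitrogen gives a 4.0-fold lower number from compound 2 to compound 3 (0.61 log units; beyond the scatter), while cyclohexyl in place of isopropyl gives a 1.1-fold higher number from compound 1 to compound 3 (0.06 log units; within the scatter) and so separates neither group from the other. Of the three groups on this nitrogen, only oxolan-3-yl stands apart from the other two, with both carbon-only groups on one level. No measurement at hand explains this difference.

On these data alone, the step from oxolan-3-yl to cyclohexyl changes ring size and removes the ring oxygen together, so the share of each stays open. Cyclopentyl and oxan-4-yl on this nitrogen would separate the two, and a piperidin-4-yl ring would test a ring amine in the same place.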